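Swapping chloro for methoxy on a growth-inhibition scaffold

The compounds below may be only part of what the source reports. "The series", "measured", "known", "first", "only" and "open" are said of these compounds alone.

Compound 1 `COc1cc(/C=C/C(=O)c2cccc(-n3cc(-c4ccc(Cl)cc4)[nH]c3=O)c2)ccc1O` is tested in a functional assay on EKVX cells (Homo sapiens) for inhibition (a higher number here means a weaker inhibitor of growth, a lower number a stronger inhibitor of growth), where compound 1 gives 9610 nM, the highest of the three values at hand. Compound 2 `COc1cc(/C=C/C(=O)c2cccc(-n3cc(-c4ccccc4)[nH]c3=O)c2)ccc1O` differs from it only by a hydrogen in place of the chloro, and in this assay compound 2 gives 3900 nM; that step, a 2.5-fold lower number from compound 1 to compound 2 (0.39 log units; beyond the scatter), shows that removing the chloro made the compound a stronger growth inhibitor. Among the compounds with values here, compound 3 `COc1ccc(-c2cn(-c3cccc(C(=O)/C=C/c4cc(OC)c(OC)c(OC)c4)c3)c(=O)[nH]2)cc1` carries a methoxyphenyl but also a different styryl end, so no single step links it to compound 1; in this assay compound 3 gives 4200 nM.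

Compound 4 `COc1ccc(-c2cn(-c3cccc(C(=O)/C=C/c4ccc(O)c(OC)c4)c3)c(=O)[nH]2)cc1` is the unmeasured case, differing from compound 1 by methoxy in place of chloro on an aromatic carbon. Within the data shown here, only the step from compound 1 to compound 2 bears directly on it, and it was a modest drop in number when the chloro left. Compound 3, which also carries methoxy at that position, sits in the same region as compound 2, though its other end differs. The expectation is therefore a modest step toward a lower number, a 2.3-fold lower number from compound 1 to compound 4 (0.36 log units; beyond the scatter), so compound 4 is expected to give about 4200 nM, most likely between 2000 nM and 9000 nM.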

Compound 4, concentration for 50% growth inhibition: 13400 nM
The estimate for compound 4 lay 3.2-fold (0.50 log units) below the measured number; the measured number lies above the stated range.
By their numbers in this assay, from the lowest: compounds 2 and 3 (each within the scatter of the next); then compounds 1 and 4 (each within the scatter of the next).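

Swapping the 4-chlorophenyl for 4-methoxyphenyl on this scaffold gives a 1.4-fold higher number from compound 1 to compound 4 (0.14 log units; within the scatter) in this assay and so makes no clear difference here, while the hydrogen of compound 2 does stand apart, with a 3.4-fold higher number from compound 2 to compound 4 (0.54 log units; beyond the scatter) alongside a 2.5-fold lower number from compound 1 to compound 2 (0.39 log units; beyond the scatter) on the chloro side, so with this 4-hydroxy-3-methoxyphenyl end, chloro and methoxy both go with a higher number than hydrogen. The other end of the molecule also counts, as a 3.2-fold higher number from compound 3 to compound 4 (0.50 log units; beyond the scatter) shows with the 4-methoxyphenyl held fixed and 4-hydroxy-3-methoxyphenyl replacing 3,4,5-trimethoxyphenyl, so the low number of compound 3 did not carry over to compound 4 at all. Nothing measured here explains why these numbers fall as they do.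

Still open, from the compounds shown here alone, is whether a fluoro, an amino group or a carboxylic acid at this position would sit with hydrogen or with chloro and methoxy. Within the data shown here, also open is whether the 3,4,5-trimethoxyphenyl end would keep its lower number with hydrogen or chloro in place of the methoxy, as compound 3 is the only compound here with that end.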